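Dimethylamino to diethylamino: expectation for compound 4

The source may report more compounds than this note shows. Statements on the series, on what has been measured and on what is new or still open speak of the compounds shown alone.

In an ADME assay on HEK293 cells (Homo sapiens) for cytotoxicity, read by MTT assay, with a stated time of 48 h (on this read-out higher numbers stand for weaker inhibition and lower numbers for stronger inhibition), compound 3 `CN(C)CCn1c(N)c(-c2nc3cc(Cl)ccc3[nH]2)c2nc(C#N)c(C#N)nc21` gives > 50000 nM, a limit of the assay and not a number. The other two measured compounds return numbers. Compound 1 `CCN(CC)CCn1c(N)c(-c2nc3ccccc3[nH]2)c2nc(C#N)c(C#N)nc21` gives 12200 nM. Compound 2 `CCN(CC)CCn1c(N)c(-c2nc3ccccc3n2C)c2nc(C#N)c(C#N)nc21` gives 25400 nM.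

Compound 4 `CCN(CC)CCn1c(N)c(-c2nc3cc(Cl)ccc3[nH]2)c2nc(C#N)c(C#N)nc21` carries diethylamino in place of dimethylamino on a saturated chain carbon, two bonds along the chain from an aromatic nitrogen. For the measured compounds named here, no measured step covers this change. Going by the values given here, the only measured step, a 2.1-fold higher number from compound 1 to compound 2 (0.32 log units; beyond the scatter), is methyl in place of hydrogen on an aromatic nitrogen, which is a different change at a different place, so it gives only a rough sense of scale. It is modest but beyond the scatter.

Compounds 1 and 2 both carry diethylamino and both give numbers in this assay, but neither has the chloro group of compound 3, so the comparison is indirect. Compound 1 at 12200 nM is the closest guide. For compound 4 a lower number than the limit of compound 3 is expected, though with wide uncertainty. The expected change is an at least 2.2-fold lower number from compound 3 to compound 4 (0.35 log units; beyond the scatter). Compound 4 is estimated at 22000 nM, with an expected range of 9000 nM to 50000 nM.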

Compound 4, half-maximal inhibitory concentration: > 50000 nM
Compound 4: a limit, no number; the forecaster's own chance of this, stated with the estimate: 20%; middle value at least 2.2-fold (0.35 log units) from the limit.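

In this assay, compound 3 and compound 4 both stand at a limit and not at a number, so the exchange of dimethylamino for diethylamino on a saturated chain carbon cannot be read from this pair: the limit of > 50000 nM in this assay, at which 2 of the 4 values shown sit.

For the compounds shown here, with diethylamino held constant, chloro in place of hydrogen on an aromatic carbon gives an at least 4.0-fold higher number from compound 1 to compound 4 (0.61 log units; beyond the scatter), the first readable step for this substitution. The exchange of 1-methyl-1H-benzimidazol-2-yl for 5-chloro-1H-benzimidazol-2-yl on an aromatic carbon gives an at least 1.9-fold higher number from compound 2 to compound 4 (0.29 log units; that floor lies within the scatter), so this pair fixes only a floor and does not by itself establish a step beyond the scatter.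

Going by these compounds alone, still open is whether dimethylamino and diethylamino differ at all in this assay, since the only pair that carries this exchange gives no number on either side. Also open, as far as these compounds go, is how a fluoro or methoxy group on that aromatic carbon, or a morpholine in place of diethylamino, would read in this assay.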